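Phenyl to nitroimidazole on a cytotoxicity readout

The compounds below may be only part of what the source reports. "The series", "measured", "known", "first", "only" and "open" are said of these compounds alone.

Compound 1 `CN1Cc2ccc(OCCc3ccccc3)cc2[C@@H](O)C1` and compound 2 `CN1Cc2ccc(OCCCc3ccccc3)cc2[C@@H](O)C1` share one core and differ only in the length of the chain that carries a phenyl group. In an ADME assay on Vero cells (Chlorocebus sabaeus) for cytotoxicity, read by sulforhodamine B assay, with a stated time of 72 h (a higher number here means a weaker inhibitor, a lower number a stronger inhibitor), compound 1 gives > 50000 nM, which is a limit of the assay rather than a number. In this assay compound 2 likewise gives > 50000 nM, again a limit. Within the data shown here, the step that the two limits leave unreadable from compound 1 to compound 2 therefore cannot be sized, and the only evidence available is the limit of > 50000 nM in this assay, at which 2 of the 2 values shown sit. Compound 3 `CN1Cc2ccc(OCCCn3ccnc3[N+](=O)[O-])cc2[C@@H](O)C1` carries 2-nitro-1H-imidazol-1-yl in place of phenyl on a saturated chain carbon, three bonds along the chain from an oxygen on an aromatic ring. Among the measured compounds shown here, no measured step describes that exchange, so the expected change is a step that the limit leaves unreadable from compound 2 to compound 3, meaning no shift beyond the usual scatter is anticipated, with the result most likely reported once more as a limit. Compound 3 is accordingly estimated at 60000 nM, within a range from 20000 nM to 200000 nM.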

Compound 3, half-maximal inhibitory concentration: > 50000 nM
Compound 3 gave a limit, no number (the forecaster's own chance of this, stated with the estimate: 80%); the middle value lies beyond the limit too.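

The step from compound 2 to compound 3 cannot be read, because both results in this assay are limits, not numbers: the limit of > 50000 nM in this assay, at which 3 of the 3 values shown sit.

Compound 1, compound 2 and compound 3 leave open whether chain length, or 2-nitro-1H-imidazol-1-yl in place of phenyl, changes cytotoxicity at all.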